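This account rests on a few compounds, and the source may have more. Where it says the series, first, only, none or still open, it means among the compounds named here.

Going by the values given here, in a functional assay on HeLa cells (Homo sapiens) for antiproliferative activity, read by sulforhodamine B assay (a lower number here means a stronger inhibitor of growth, a higher number a weaker inhibitor of growth), compound 2 `CC(C)C[C@H]1O[C@H](COCc2ccccc2)[C@@H](OCc2ccccc2)[C@H](OCc2ccccc2)[C@H]1O` gives 43900 nM, the only exact number available so far. Compound 1 `CC(C)C[C@@H]1O[C@H](COCc2ccccc2)[C@@H](OCc2ccccc2)[C@H](OCc2ccccc2)[C@H]1O` is recorded only as a limit, > 50000 nM. The two structures are stereoisomers, and the fact that compounds 1 and 2 differ only in the configuration as drawn is the sole structural contrast between them. The step of an at least 1.1-fold lower number from compound 1 to compound 2 (0.05 log units; that floor lies within the scatter) does not separate them beyond the scatter, and one end of it rests on (the limit of > 50000 nM in this assay, at which 1 of the 2 values shown sits).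

The next compound, compound 3 `CC(C)C[C@@H]1O[C@H](COCc2ccccc2)[C@@H](OCc2ccccc2)[C@H](OCc2ccccc2)[C@@H]1O`, keeps every atom and bond of compound 2 and changes only its drawn configuration: the two compounds have the same atoms and bonds and differ only in configuration as drawn: 2 of 5 stereo elements differ; a stereocentre at a saturated ring carbon is drawn R in compound 2 and S in compound 3; a stereocentre at a saturated ring carbon is drawn S in compound 2 and R in compound 3. No group leaves or enters. Among the compounds with values here, the step between compound 1 and compound 2 is the only measured guide to a change of this kind, and it involves a single stereocentre, whereas two change here. That guide gives no reason to expect a real shift in this assay in either direction, although a result reported only as a limit would be no surprise. The expected step is a 1.0-fold higher number from compound 2 to compound 3 (0.01 log units; within the scatter), which would lie within the scatter. For compound 3 the estimated value is 45000 nM, with an expected range from 20000 nM to 90000 nM.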

Compound 3, concentration for 50% growth inhibition: 24600 nM
Beside the measured number, compound 3's estimate is 1.8-fold (0.26 log units) above it, and the stated range covers the measured number.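

In this assay, going by these compounds alone, the step of a 1.8-fold lower number from compound 2 to compound 3 (0.25 log units; within the scatter) is the first comparison with an exact number at both ends, and it shows that changing the drawn configuration at two saturated ring carbons together leaves the reading within the scatter. The step of an at least 2.0-fold lower number from compound 1 to compound 3 (0.30 log units; that floor lies within the scatter) concerns a single stereocentre at a saturated ring carbon, a different one from the stereocentre that separates compound 1 from compound 2, and its floor also lies within the scatter. That step rests on a limit, since compound 1 is recorded only as > 50000 nM, so its full size cannot be read.

All the compounds shown share the same atoms and bonds, which leaves open whether any change other than configuration would move the number in this assay. On these data alone, what an amine or a carboxylic acid in place of the hydroxyl group, or a longer chain in place of the isobutyl group, would do to growth inhibition also remains open.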